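From 6-chloropyridin-3-yl to 3-chlorophenyl: working notes

This account rests on a few compounds, and the source may have more. Where it says the series, first, only, none or still open, it means among the compounds named here.

In a functional assay on HCT-116 cells (Homo sapiens) for cytotoxicity, read by MTT assay, with a stated time of 72 h (on this read-out higher numbers stand for weaker inhibition and lower numbers for stronger inhibition), compound 1 (`Nc1ccccc1NC(=O)c1ccc(CNC(=O)c2cc3cccnc3[nH]2)cc1`) gives 10000 nM as its reading. Compound 2 (`Nc1ccccc1NC(=O)c1ccc(NC(=S)NCc2ccc(Cl)nc2)cc1`) stands at 6100 nM on the same read-out. That is within the scatter of compound 1, and these two numbers allow no ranking.

Compound 3 (`Nc1ccccc1NC(=O)c1ccc(NC(=S)NCc2cccc(Cl)c2)cc1`) has not yet been measured. It carries 3-chlorophenyl in place of 6-chloropyridin-3-yl on a saturated chain carbon bound to an amide-type nitrogen and otherwise matches compound 2. Among the measured compounds shown here, no measured pair shows the effect of such an exchange, and compound 1 differs from compound 2 in more than one place, so it offers no direct guide.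

The expectation therefore rests on compound 2 at 6100 nM as the sole anchor. No step beyond the scatter is expected in this assay and the data argue for no direction. The estimated step (a 1.2-fold lower number from compound 2 to compound 3 (0.09 log units; within the scatter)) stays inside the scatter. For compound 3 the expected value is 5000 nM with an estimated range from 2000 nM to 12000 nM as the working figure.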

Compound 3, half-maximal inhibitory concentration: 5900 nM
Beside the measured number, compound 3's estimate is 1.2-fold (0.07 log units) below it; measured number inside the range.
By their numbers in this assay, from the lowest: compounds 3, 2 and 1 (each within the scatter of the next).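

Compound 3 gives the series its first pair that differs in one place: in this assay, 3-chlorophenyl in place of 6-chloropyridin-3-yl on a saturated chain carbon bound to an amide-type nitrogen amounts to a 1.0-fold lower number from compound 2 to compound 3 (0.01 log units; within the scatter). At this position, then, a ring of carbon only with 0 hydrogen-bond acceptors and a ring with 1 hetero atom and 1 hydrogen-bond acceptor read alike in this assay, and the pair gives no ranking of the two groups. No measurement at hand speaks to the reason for this result.

The compounds shown leave open how this position responds to groups further from these two, such as a carboxylic acid or an amine on the ring in place of the chlorine, or a longer chain carrying the same ring. Whether any such group would give a step beyond the scatter in this assay cannot be read from a single exchange at a single position.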